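This account rests on a few compounds, and the source may have more. Where it says the series, first, only, none or still open, it means among the compounds named here.

In an ADME assay on MT4 cells (Homo sapiens) for cytotoxicity, read by spectrophotometry, with a stated time of 5 days (on this read-out higher numbers stand for lower toxicity in this test and lower numbers for higher toxicity in this test), compound 1 (`Cc1ccc2c(c1)/C(=N/NC(=S)NO)C(=O)N2CN1CCN(c2ccc(Cl)cc2)CC1`) gives 335000 nM and compound 2 (`O=C1/C(=N\NC(=S)NO)c2cc(F)ccc2N1CN1CCN(c2ccc(Cl)cc2)CC1`) gives 194000 nM under the same conditions. Compound 3 (`COc1ccc(N2CCN(CN3C(=O)/C(=N\NC(=S)NO)c4cc(Cl)ccc43)CC2)cc1`) gives 279000 nM and so stands within the scatter of both. Compound 4 (`O=C1/C(=N\NC(=S)NO)c2cc(Cl)ccc2N1CN1CCN(c2ccc(Cl)cc2)CC1`) keeps the core of compound 3 but changes 4-methoxyphenyl to 4-chlorophenyl, with chloro in place of methoxy on an aromatic carbon is the whole difference. For the measured compounds named here, no measured step makes this exchange. Going by the values given here, the only step available, a 1.7-fold lower number from compound 1 to compound 2 (0.24 log units; within the scatter) for fluoro in place of methyl on an aromatic carbon, is a different swap and bears on it only indirectly. It stays within the scatter. Compound 1 at 335000 nM and compound 2 at 194000 nM already carry the 4-chlorophenyl and remain within the scatter of compound 3, so no shift beyond the scatter is expected in this assay here. The estimated change is a 1.2-fold lower number from compound 3 to compound 4 (0.07 log units; within the scatter) and is expected to be small. For compound 4 the expected value is 240000 nM with an estimated range from 130000 nM to 420000 nM for now.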

Compound 4, half-maximal cytotoxic concentration: 268000 nM
The estimate for compound 4 lay 1.1-fold (0.05 log units) below the measured number, and the stated range covers the measured number.
By their numbers in this assay, from the lowest: compounds 2, 4, 3 and 1 (each within the scatter of the next).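

In this assay, for the compounds shown here, the first reading of the change from 4-methoxyphenyl to 4-chlorophenyl, on an aromatic carbon para to a large group, is a 1.0-fold lower number from compound 3 to compound 4 (0.02 log units; within the scatter) and shows that this exchange leaves the number within the scatter. Going by these compounds alone, compound 4 also gives the first readings at the other place that varies on the shared core: chloro in place of fluoro gives a 1.4-fold higher number from compound 2 to compound 4 (0.14 log units; within the scatter) and chloro in place of methyl gives a 1.3-fold lower number from compound 1 to compound 4 (0.10 log units; within the scatter), so all three exchanges stay within the scatter in this assay. No measurement given here explains why these numbers stay so close.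

Going by these compounds, only methoxy and chloro have been compared at the para place, so the effect of an amine, a carboxylic acid or a longer chain there remains open. On these data alone, whether the exchanges would stay this small in any other test also remains open.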